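The source may hold more compounds than are shown below. What is called first, only, known or untested is meant among the compounds shown, and "the series" means these compounds.

Compound 1 `NCCCc1ccc(-c2ccc(-c3ccc(-c4cccs4)s3)s2)s1` was tested in an ADME assay on MDCK cells (Canis lupus familiaris) for cytotoxicity, read by MTT assay, with a stated time of 2 days; a lower number here means that less compound is tolerated, a higher number that more compound is tolerated. In this assay compound 1 gives only a limit of the assay, > 200000 nM, and no single number. This is the limit of > 200000 nM in this assay, at which 1 of the 3 values shown sits. Compound 2 `BrCCCCc1ccc(-c2ccc(-c3ccc(-c4cccs4)s3)s2)s1` was not measured, so in this assay compound 2 gives "not determined" (no result reported). Compound 3 `O=C(NCCCc1ccc(-c2cccs2)s1)c1cc(F)cc(C(F)(F)F)c1` gives 46700 nM in this assay, a number rather than a limit. Compound 4 `NCCCc1ccc(-c2ccc(-c3ccc(CCCN)s3)s2)s1` has not yet been measured; it differs from compound 1 by 3-aminopropyl in place of thiophen-2-yl on an aromatic carbon. Within the data shown here, no step between measured compounds covers this change, so the expectation for compound 4 rests on compound 1 alone. The expected step is a step that the limit leaves unreadable from compound 1 to compound 4, which is no change beyond the usual scatter. Compound 4 is therefore estimated at 250000 nM, within a range from 80000 nM to 600000 nM, and it may again be reported only as a limit.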

Compound 4, half-maximal cytotoxic concentration: > 200000 nM
Compound 4 gave a limit, no number; the forecaster's own chance of this, stated with the estimate: 70%; the middle value is on the limit's open side.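

Compound 1 and compound 4 each give only a limit in this assay, not a number, so no step can be read between them: the limit of > 200000 nM in this assay, at which 2 of the 4 values shown sit.

On these data alone, whether 3-aminopropyl in place of thiophen-2-yl changes the tolerated concentration at all stays open.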